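Exposure of Two Halogen Compounds and One Untested Analogue

The compounds below may be only part of what the source reports. "The series", "measured", "known", "first", "only" and "open" are said of these compounds alone.

Compound 1 `CCOC(=O)c1c(-c2cccc(Cl)c2)[nH]c2cc(OC)c(F)cc2c1=O` gives 38000 nM
Compound 2 `CCOC(=O)c1c(-c2cccc(Br)c2)[nH]c2cc(OC)c(F)cc2c1=O` gives 31000 nM

In an in vivo ADME assay on the whole organism (strain CD1) for pharmacokinetics, with Mus musculus as the target, at a dose of 50 mg/kg by the oral route (on this read-out lower numbers stand for lower exposure and higher numbers for higher exposure at the dose given), compound 2 gives 31000 nM and stands within the scatter of compound 1, which gives 38000 nM. The next structure, compound 3 `CCOC(=O)c1c(-c2cc(F)cc(OC)c2)[nH]c2cc(OC)c(F)cc2c1=O`, has 3-fluoro-5-methoxyphenyl in place of 3-bromophenyl on an aromatic carbon. For the measured compounds named here, only one measured step bears on this change, and it is a 1.2-fold lower number from compound 1 to compound 2 (0.09 log units; within the scatter). That step exchanges one halogen for another, while neither measured compound carries the 3-fluoro-5-methoxyphenyl group, so it offers only weak guidance. No step beyond the scatter is therefore expected, and no direction is firmly indicated. The expected change is a 1.2-fold lower number from compound 2 to compound 3 (0.09 log units; within the scatter). In this assay, compound 3 is estimated at 25000 nM, with an expected range from 9000 nM to 70000 nM.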

Compound 3, maximal plasma concentration: 710 nM
Compound 3: the middle estimate sits 35-fold (1.55 log units) above what was measured, and the stated range ends above it.
By their numbers in this assay, from the lowest: compound 3; then compounds 2 and 1 (each within the scatter of the next).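

In this assay, compound 1 and compound 2 showed only that chloro and bromo on this phenyl group stand within the scatter of each other, which said little about how much the position, on an aromatic carbon next to the ring nitrogen, could matter. The new result shows that it can matter a great deal: 3-fluoro-5-methoxyphenyl in place of 3-bromophenyl gives a 44-fold lower number from compound 2 to compound 3 (1.64 log units; beyond the scatter), and in place of 3-chlorophenyl it gives a 54-fold lower number from compound 1 to compound 3 (1.73 log units; beyond the scatter). Nothing measured here accounts for these steps.

The compounds shown leave open whether the fluoro, the methoxy or the two together go with the lower exposure, a question that a 3-methoxyphenyl or a 3-fluorophenyl group at this position would separate. They also leave open how an amine on this phenyl group would read out.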